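Ester variations on the shared core: toward compound 4

The source may report more compounds than this note shows. Statements on the series, on what has been measured and on what is new or still open speak of the compounds shown alone.

Measured so far in an assay on HEK293T cells for inhibition of nuclear factor NF-kappa-B complex (Homo sapiens), read by a luciferase reporter; on this read-out higher numbers stand for weaker inhibition and lower numbers for stronger inhibition:
- compound 1 `COc1cc2c(c(O)c1C(=O)/C=C/c1ccc(OC(=O)c3cccs3)cc1)CCC(C)(C)O2`: > 30000 nM, a limit of the assay and not a number.
- compound 2 `CCCCC(=O)Oc1ccc(/C=C/C(=O)c2c(OC)cc3c(c2O)CCC(C)(C)O3)cc1`: > 30000 nM, likewise a limit.
- compound 3 `COc1cc2c(c(O)c1C(=O)/C=C/c1ccc(OC(=O)c3ccc(OC(F)(F)F)cc3)cc1)CCC(C)(C)O2`: > 30000 nM, likewise a limit.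

Compound 1 stands only at a limit in this assay; all three measured values sit at the same limit, as the limit of > 30000 nM in this assay, at which 3 of the 3 values shown sit, records. The steps a step that the two limits leave unreadable from compound 1 to compound 2, a step that the two limits leave unreadable from compound 1 to compound 3 and a step that the two limits leave unreadable from compound 2 to compound 3 therefore cannot be read in size or direction: exchanging thiophen-2-yl for butyl or for 4-(trifluoromethoxy)phenyl on the carbonyl carbon leaves every compound beyond the limit.

Compound 4 `C=CCOC(=O)Oc1ccc(/C=C/C(=O)c2c(OC)cc3c(c2O)CCC(C)(C)O3)cc1` is the next member to be measured. Its difference from compound 1 is allyloxy in place of thiophen-2-yl on a carbonyl carbon. All three measured steps bear on it in kind, since each also varies the group on that carbonyl carbon, but none gives a readable size. Among the compounds with values here, no measured step points in either direction, so no step beyond the scatter is expected, and compound 4 is estimated to remain at the limit, with a step that the limit leaves unreadable from compound 1 to compound 4 as the implied step. The estimate for compound 4 is 40000 nM, within 15000 nM to 100000 nM.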

Compound 4, half-maximal inhibitory concentration: > 30000 nM
Compound 4 gave a limit, no number; the forecaster's own chance of this, stated with the estimate: 85%; the middle value does not contradict the limit.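

Within the data shown here, compound 4 also gives a limit and not a number in this assay, so no step among compound 1, compound 2, compound 3 and compound 4 can be read in size or direction: the limit of > 30000 nM in this assay, at which 4 of the 4 values shown sit. The compounds shown leave open whether any group on the carbonyl carbon of the shared core gives a measurable value in this assay.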